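Triazole series: ester chain and aryl swap in cell inhibition

The source may report more compounds than this note shows. Statements on the series, on what has been measured and on what is new or still open speak of the compounds shown alone.

Measured compounds:
Compound 1, `COC(=O)c1cc(-n2cc(-c3cc(O)ccc3O)nn2)ccc1O`: 52%
Compound 2, `COC(=O)c1cc(-n2cc(-c3ccc(OC)cc3)nn2)ccc1O`: 16%
Compound 3, `O=C(OCCCc1ccccc1)c1cc(-n2cc(-c3cc(O)ccc3O)nn2)ccc1O`: 81%

In a functional assay on CCRF-CEM cells (Homo sapiens) for inhibition, read by MTT assay, with a stated time of 2 days, tested at 10 uM (a lower number here means less inhibition, a higher number more inhibition at the concentration tested (going by the name of the read-out)), compound 1 gives 52%. Two changes to compound 1 are measured. The first, (4-methoxyphenyl in place of 2,5-dihydroxyphenyl on an aromatic carbon), gives a number 36 percentage points lower from compound 1 to compound 2 (beyond the scatter). The second, (phenethyl in place of hydrogen on a saturated chain carbon bound to an oxygen next to a carbonyl group), gives a number 29 percentage points higher from compound 1 to compound 3 (beyond the scatter), and compound 3 stands highest of the three measured compounds in this assay, beyond the scatter to both others.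

Compound 4, `COc1ccc(-c2cn(-c3ccc(O)c(C(=O)OCCCc4ccccc4)c3)nn2)cc1`, is not yet measured in this assay. It differs from compound 3 by 4-methoxyphenyl in place of 2,5-dihydroxyphenyl on an aromatic carbon. The same change, in the same place, has been made once already, from compound 1 to compound 2, where it made a number 36 percentage points lower from compound 1 to compound 2 (beyond the scatter). The two cores on which the change is made are not the same: they differ by phenethyl in place of hydrogen on a saturated chain carbon bound to an oxygen next to a carbonyl group, so the transfer of the step rests on a single earlier instance on a different core.

Among the measured compounds shown here, for compound 4 the expected step is a number 36 percentage points lower from compound 3 to compound 4 (beyond the scatter), taken from the earlier step from compound 1 to compound 2, because that step a number 36 percentage points lower from compound 1 to compound 2 (beyond the scatter) is the only measurement of this change. Compound 4 is therefore estimated at 45% in this assay. For the measured compounds named here, the range for compound 4 is expected to run from 25% to 65%, wide because the step of a number 36 percentage points lower from compound 1 to compound 2 (beyond the scatter) is the single pair from which it is carried over, and that pair sits on another core.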

Compound 4, a percentage reported as inhibition, at one concentration (the size of the read-out at that concentration, not a potency): 5%
Beside the measured number, compound 4's estimate is 40 percentage points above it, and the stated range ends above it.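

In this assay, 4-methoxyphenyl in place of 2,5-dihydroxyphenyl again lowers the number on the core carrying the longer ester, with a number 76 percentage points lower from compound 3 to compound 4 (beyond the scatter), so the direction of the step carries over but its size does not: the same change on two cores in this assay, a number 36 percentage points lower (beyond the scatter) from compound 1 to compound 2 and a number 76 percentage points lower (beyond the scatter) from compound 3 to compound 4, 40 percentage points apart, beyond the scatter of two such steps. The ester change depends on the aryl group in the same way, since on the 4-methoxyphenyl compounds it gives a number 11 percentage points lower from compound 2 to compound 4 (beyond the scatter), opposite in direction to its step on the 2,5-dihydroxyphenyl compounds: the same change on two cores in this assay, a number 29 percentage points higher (beyond the scatter) from compound 1 to compound 3 and a number 11 percentage points lower (beyond the scatter) from compound 2 to compound 4, 40 percentage points apart, beyond the scatter of two such steps. Across these four compounds the two changes therefore do not add independently, and a step measured on one core is a poor guide to its size on the other, but two pairs at a single concentration show neither the reason for this nor how general it is.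

The compounds shown leave open which part of the aryl swap matters, a question that aryl groups such as 4-hydroxyphenyl or 2,5-dimethoxyphenyl would help to separate. They also leave open whether the same dependence appears with other groups on the ester end, such as a free carboxylic acid, an amide or a benzyl ester.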